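This account rests on a few compounds, and the source may have more. Where it says the series, first, only, none or still open, it means among the compounds named here.

Going by the values given here, the two compounds measured so far were tested in a functional assay on HeLa cells (Homo sapiens) for inhibition, read by transwell migration, with a stated time of 24 h, tested at 10 uM; on this read-out lower numbers stand for less inhibition and higher numbers for more inhibition at the one concentration tested (going by the name of the read-out). Compound 1 `CN(C(=O)c1ccccc1)c1nc(-c2ccccc2)cs1` gives 60% in this assay. Compound 2 `Cn1c(-c2ccccc2)cs/c1=N/C(=O)c1ccccc1` gives 60% in this assay, so on the numbers shown compound 2 stands level with compound 1, the two values lying within the usual scatter of each other.

The step of interest leads from compound 2 to compound 3 `Cn1c(-c2ccccc2)cs/c1=N/C(=O)c1ccc(Cl)cc1`, which is not yet measured. The difference between the two structures is chloro in place of hydrogen on an aromatic carbon. Among the compounds with values here, nothing among the measured compounds shows what this change does in this assay, so the expectation rests on the one measured value of compound 2 alone. The step of no change at the digits printed from compound 2 to compound 3 (within the scatter) is expected to be small, not beyond the scatter in either direction. For compound 3 the estimate in this assay is 60%, with a range from 45% to 75%.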

Compound 3, a percentage reported as inhibition, at one concentration (the size of the read-out at that concentration, not a potency): 60%
Beside the measured number, compound 3's estimate shows no gap at the digits printed, and the stated range covers the measured number.
By their numbers in this assay, from the lowest: compounds 1, 2 and 3 (each within the scatter of the next).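

Replacing hydrogen with chloro on an aromatic carbon, para to a large group, turns phenyl into 4-chlorophenyl and gives no change at the digits printed from compound 2 to compound 3 (within the scatter) in this assay. Going by these compounds alone, this is the first view of a substituent at this place, and it shows that this ring can carry a chlorine atom with the two compounds still level at the one concentration tested. The result does not show how strongly either compound acts across a range of concentrations, and no measurement on hand bears on why the two read the same.

On these data alone, it remains open whether an amine, a carboxylic acid or a longer chain such as butyl at this place would also leave the value level. The compounds shown also leave open what chloro would do on another carbon of this ring.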